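A few compounds are considered here, and "the series" means these few. Any claim that something is new, unique, unknown or untested is made for them only; others in the source may bear on it.

Compound 1 `S=C(Nc1ccccc1Cl)OCCc1ccccn1` gives > 100000 nM in an ADME assay on MT4 cells (Homo sapiens) for cytotoxicity, read by MTT assay (on this read-out lower numbers stand for higher toxicity in this test and higher numbers for lower toxicity in this test), which is a limit of the assay rather than a number. Compound 2 `S=C(Nc1cccc(Cl)c1)OCCc1ccccn1` gives 47000 nM. Compound 3 `Cc1ccc(NC(=S)OCCc2ccccn2)cc1` gives 75000 nM.

Among the two numbers shown, compound 3 and compound 2 sit within the scatter of each other, so no order between them can be stated. The third value is the one of the limit of > 100000 nM in this assay, at which 1 of the 3 values shown sits.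

Compound 4 `S=C(Nc1ccc(Cl)cc1)OCCc1ccccn1` has not yet been measured. It differs from compound 3 by chloro in place of methyl on an aromatic carbon. No measured step of this kind is shown, so the step from compound 3 to compound 4 is expected to be small, in no fixed direction, and likely not beyond the scatter, giving an estimated 1.3-fold lower number from compound 3 to compound 4 (0.10 log units; within the scatter). Compound 4 is therefore expected to give about 60000 nM, within a range from 25000 nM to 120000 nM.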

Compound 4, half-maximal cytotoxic concentration: 52000 nM
The estimate for compound 4 lay 1.2-fold (0.06 log units) above the measured number, within the range that was stated.
By their numbers in this assay, from the lowest: compounds 2, 4 and 3 (each within the scatter of the next). At a limit, above all of these: compound 1.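

On the aromatic carbon para to a large group, chloro in place of methyl gives in this assay a 1.4-fold lower number from compound 3 to compound 4 (0.16 log units; within the scatter) and so does not tell the two groups apart. Compound 4 and compound 2, which carry chloro at different places, also stay within the scatter of each other. Nothing measured here gives a reason for the step. Still open, on these data alone, is whether an amine or a carboxylic acid on this aromatic carbon would move the number beyond the scatter. A longer chain on the shared core remains equally untested by these compounds.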